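Cytotoxicity notes: compound 4 set against compounds 1 to 3

The compounds below may be only part of what the source reports. "The series", "measured", "known", "first", "only" and "open" are said of these compounds alone.

Measured so far:
compound 1 `CC(C)=CCOc1cc(Nc2ncnc(Cl)n2)ccc1Cl` gives 45000 nM in an ADME assay on MT2 cells (Homo sapiens) for cytotoxicity; a higher number here means that more compound is tolerated, a lower number that less compound is tolerated
compound 2 `COc1nc(Cl)nc(Nc2ccc(Cl)c(OCC=C(C)C)c2)n1` gives 26000 nM in this assay
compound 3 `CC(C)=CCOc1cc(Nc2ncnc(Cl)n2)ccc1C#N`: only a limit, > 100000 nM in this assay

Compound 1 holds the higher of the two plain numbers in this assay, with compound 2 nearest: a 1.7-fold lower number from compound 1 to compound 2 (0.24 log units; within the scatter). The value of compound 3 is a limit of this assay, not a number (the limit of > 100000 nM in this assay, at which 1 of the 3 values shown sits).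

Compound 4 `CC(C)=CCOc1cc(Nc2nccc(N)n2)ccc1Cl` is not yet measured. It differs from compound 1 by 4-aminopyrimidin-2-yl in place of 4-chloro-1,3,5-triazin-2-yl on a nitrogen on an aromatic ring. Neither measured step touches this place: a 1.7-fold lower number from compound 1 to compound 2 (0.24 log units; within the scatter) sits on an aromatic carbon, and an at least 2.2-fold higher number from compound 1 to compound 3 (0.34 log units; beyond the scatter) likewise. Going by the values given here, no measured step therefore bears on the change, and no step beyond the scatter is expected in this assay; the estimate for compound 4 is 55000 nM (range 20000 nM to 150000 nM), meaning a 1.2-fold higher number from compound 1 to compound 4 (0.09 log units; within the scatter).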

Compound 4, half-maximal cytotoxic concentration: 500 nM
Compound 4: middle estimate off by 110-fold (2.04 log units), on the high side, outside the stated range (below it).
By their numbers in this assay, from the lowest: compound 4; then compounds 2 and 1 (each within the scatter of the next). At a limit, above all of these: compound 3.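

Going by these compounds alone, the group on the nitrogen on an aromatic ring proves to be a sensitive place in this assay, a point the earlier steps on aromatic carbons could not show: 4-aminopyrimidin-2-yl in place of 4-chloro-1,3,5-triazin-2-yl gives a 90-fold lower number from compound 1 to compound 4 (1.95 log units; beyond the scatter). No measurement shown gives a cause for this step.

Still open, going by these compounds, is whether the drop follows the ring change or the amino group, since both differ at once. A 4-chloropyrimidin-2-yl group on the same nitrogen would separate the two.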